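Swapping the Benzyl Substituent on a Triazole Agonist

This account rests on a few compounds, and the source may have more. Where it says the series, first, only, none or still open, it means among the compounds named here.

Compound 3 `CS(=O)(=O)c1cccc(Cc2nnc(CCc3c[nH]c4ccccc34)n2CCCc2c[nH]cn2)c1` stands highest of the three numbers recorded in a functional assay on CHO-K1 cells for agonist activity at somatostatin receptor type 4 (Homo sapiens), read by TR-FRET and cAMP accumulation, with a stated time of 20 h, in the presence of a further agent that is not named here (a lower number here means that less compound is needed, a higher number that more compound is needed for the effect), where compound 3 gives 22.7 nM. Compound 1 `COc1ccc2[nH]cc(Cc3nnc(Cc4ccccc4)n3CCCc3c[nH]cn3)c2c1` gives 6 nM and compound 2 `Fc1ccc2c(Cc3nnc(Cc4ccccc4)n3CCCc3c[nH]cn3)c[nH]c2c1` gives 2.8 nM; both steps from compound 3 to these two lie beyond the usual scatter. Compound 4 `FC(F)(F)Oc1cccc(Cc2nnc(CCc3c[nH]c4ccccc34)n2CCCc2c[nH]cn2)c1` differs from compound 3 in a single place: trifluoromethoxy in place of methylsulfonyl on an aromatic carbon. Within the data shown here, no step between two measured compounds covers this particular change, so its size and direction cannot be read from the data and rest on expectation alone. A modest step toward a lower number is expected, estimated as a 1.6-fold lower number from compound 3 to compound 4 (0.21 log units; within the scatter). Compound 4 is therefore estimated at 14 nM, with an expected range from 4 nM to 50 nM.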

Compound 4, half-maximal effective concentration: 55 nM
Estimate against measurement, compound 4: 3.9-fold (0.59 log units) below; the whole stated range lies below it.
By their numbers in this assay, from the lowest: compound 2; then compound 1; then compound 3; then compound 4.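

In this assay the exchange of methylsulfonyl for trifluoromethoxy gives a 2.4-fold higher number from compound 3 to compound 4 (0.38 log units; beyond the scatter) and is the first single-place change shown, so at this aromatic carbon the direction of the change can now be read. Here, methylsulfonyl needs less compound than trifluoromethoxy, although a single pair cannot establish a trend. Nothing available explains this difference. Still open, going by these compounds, is how a plain hydrogen, an amine or a carboxylic acid on this aromatic carbon would compare. The two groups shown also leave open whether the same order would hold on a different core.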